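This account rests on a few compounds, and the source may have more. Where it says the series, first, only, none or still open, it means among the compounds named here.

Compound 1 `CCOC(=O)c1c(-c2cccc(-c3ccccc3)c2)[nH]c2cc(OC)ccc2c1=O` is tested in an ADME assay on HEK293 cells (Homo sapiens) for cytotoxicity, read by luminescence, with a stated time of 72 h; on this read-out higher numbers stand for an effect only at larger amounts of compound and lower numbers for an effect already at smaller amounts. There compound 1 gives > 22000 nM, which is a limit of the assay and not a number. Compound 2 `CCOC(=O)c1c(-c2cccc(N(C)C)c2)[nH]c2cc(OC)ccc2c1=O` gives > 22000 nM, which is also a limit. Compound 3 `CCOC(=O)c1c(-c2cccc(-c3ccccc3)c2)[nH]c2cc(OC(C)C)ccc2c1=O` differs from compound 1 in one small group: isopropyl in place of methyl on an oxygen on an aromatic ring. In words, this is isopropyl in place of methyl on an oxygen on an aromatic ring, or methoxy to isopropoxy. Among the measured compounds shown here, the only measured step, a step that the two limits leave unreadable from compound 1 to compound 2, falls on an aromatic carbon rather than on that oxygen, and it gives no size to carry over. What remains is the limit of > 22000 nM in this assay, at which 2 of the 2 values shown sit. Starting from compound 1 at > 22000 nM, a limit, compound 3 is expected to show no step beyond the scatter. The expected step is a number no higher from compound 1 to compound 3 (the limit leaves the size open). For compound 3 the estimate is 22000 nM, with an expected range from 13000 nM to 40000 nM.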

Compound 3, half-maximal effective concentration: > 22000 nM
Compound 3 gave a limit, no number; the forecaster's own chance of this, stated with the estimate: 85%; the middle value sits exactly at the limit.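

In this assay compound 1 and compound 3 both give only a limit, so the change from methoxy to isopropoxy yields no readable step. The compounds shown leave open how large a concentration any of them would need for a measurable effect, with every result so far being the same limit: the limit of > 22000 nM in this assay, at which 3 of the 3 values shown sit.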